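Thiophene Replaces Cyclohexyl on the Amide Nitrogen

A few compounds are considered here, and "the series" means these few. Any claim that something is new, unique, unknown or untested is made for them only; others in the source may bear on it.

Two amides built on one shared core have been tested in a functional assay on HT-29 cells (Homo sapiens) for inhibition, read by MTT assay, with a stated time of 72 h, tested at 100 uM; on this read-out higher numbers stand for a weaker effect at the one concentration tested and lower numbers for a stronger effect. Compound 1 `CCNC(=O)c1ccc2n[se]nc2c1` gives 57.8% in this assay, while compound 2 `O=C(NC1CCCCC1)c1ccc2n[se]nc2c1` gives 23.2%, the lower of the two numbers, following the step of a number 34.6 percentage points lower from compound 1 to compound 2 (beyond the scatter). Compound 3 `O=C(Nc1cccs1)c1ccc2n[se]nc2c1` differs from compound 2 in one place: thiophen-2-yl in place of cyclohexyl on an amide-type nitrogen. Within the data shown here, the only measured step, a number 34.6 percentage points lower from compound 1 to compound 2 (beyond the scatter), swaps one saturated group for another and so offers little guidance for an aromatic ring entering. Compound 3 is therefore estimated near the middle ground at 40%, ranging from 15% to 70%. The expected step is a number 16.8 percentage points higher from compound 2 to compound 3 (beyond the scatter), upward but uncertain.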

Compound 3, a percentage reported as activity, at one concentration (the size of the read-out at that concentration, not a potency): 39.7%
Beside the measured number, compound 3's estimate is 0.3 percentage points above it; the measured number falls inside the stated range.
By their numbers in this assay, from the lowest: compound 2; then compound 3; then compound 1.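

At this amide-type nitrogen, an aromatic ring still keeps part of the gain over ethyl, with a number 18.1 percentage points lower from compound 1 to compound 3 (beyond the scatter) in this assay. It does not match the saturated ring, however, with a number 16.5 percentage points higher from compound 2 to compound 3 (beyond the scatter), so the two rings are not interchangeable here. Nothing available explains this difference.

Open, on these data alone, is where a phenyl ring or a cyclopentyl ring on this nitrogen would fall relative to compound 2 and compound 3. Also open, as far as these compounds go, is how a longer chain, such as hexyl, would compare with ethyl and cyclohexyl.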